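This account rests on a few compounds, and the source may have more. Where it says the series, first, only, none or still open, it means among the compounds named here.

Of the compounds shown here, three sharing one core have been measured in an assay on HEK293 cells for inhibition of Steryl-sulfatase (Homo sapiens), tested at 1 uM; on this read-out lower numbers stand for a weaker effect and higher numbers for a stronger effect at the one concentration tested. Compound 1 `CN(C)CCN(CCN(C)C)c1cccc(C(=O)N2CCc3ccc(OS(N)(=O)=O)cc3C2)c1` gives 17.1%, the lowest of the three numbers. Compound 2 `CC(C)CCN(CCC(C)C)c1ccc(C(=O)N2CCc3ccc(OS(N)(=O)=O)cc3C2)cc1` gives 90.8%, and compound 3 `CN(C)CCN(Cc1ccccc1)c1ccc(C(=O)N2CCc3ccc(OS(N)(=O)=O)cc3C2)cc1` gives 57.8%; both sit beyond the scatter above compound 1. Compound 4 `CN(CCCN1CCCCC1)c1cccc(C(=O)N2CCc3ccc(OS(N)(=O)=O)cc3C2)c1` differs from compound 1 in one place: methyl(3-(piperidin-1-yl)propyl)amino in place of bis(2-(dimethylamino)ethyl)amino on an aromatic carbon. For the measured compounds named here, no pair of measured compounds differs by exactly this change, so the size of the step is uncertain. Given that compound 3 gives 57.8% and compound 2 gives 90.8%, an upward step from the position of compound 1 is expected in this assay, of moderate size, a number 22.9 percentage points higher from compound 1 to compound 4 (beyond the scatter). Compound 4 is therefore estimated at 40%, with a range from 15% to 70%.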

Compound 4, a percentage reported as inhibition, at one concentration (the size of the read-out at that concentration, not a potency): 30.6%
The estimate for compound 4 lay 9.4 percentage points above the measured number; the measured number falls inside the stated range.
By their numbers in this assay, from the lowest: compound 1; then compound 4; then compound 3; then compound 2.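

In this assay, methyl(3-(piperidin-1-yl)propyl)amino in place of bis(2-(dimethylamino)ethyl)amino on this aromatic carbon gives a modest gain, a number 13.5 percentage points higher from compound 1 to compound 4 (beyond the scatter), so the read-out at this position responds to the amine substituent even though the heavy-atom count stays the same. The change removes one nitrogen and brings in a six-membered non-aromatic ring, and this single pair cannot separate those two differences. Nothing measured here bears on the origin of the step.

The compounds shown leave open how a morpholine ring in place of the piperidine would read at this position. They also leave open the effect of a longer chain leading to that ring.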